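This account rests on a few compounds, and the source may have more. Where it says the series, first, only, none or still open, it means among the compounds named here.

Measured so far, in an assay on HEK293 cells for inhibition of Indoleamine 2,3-dioxygenase 1 (Homo sapiens), with a stated time of 30 min; a higher number here means that more compound is needed for the effect, a lower number that less compound is needed:
- compound 1 `Brc1ccc2[nH]c(-c3cncn3Cc3ccccc3)cc2c1` gives 11000 nM
- compound 2 `c1ccc(Cn2cncc2-c2cc3ccccc3[nH]2)cc1` gives 10800 nM
- compound 3 `Cc1ccc(Cn2cncc2-c2cc3cc(Br)ccc3[nH]2)cc1` gives 4290 nM

Compound 3 gives the lowest of the three numbers in this assay; its distance to compound 2 and to compound 1 lies beyond the scatter in each case, so on present data it is the most potent of the three. Compound 4 `N#Cc1ccc(Cn2cncc2-c2cc3cc(Br)ccc3[nH]2)cc1` differs from compound 3 in one place: cyano in place of methyl on an aromatic carbon. For the measured compounds named here, no measured pair shows cyano in place of methyl. Going by the values given here, the only step at that carbon is a 2.6-fold lower number from compound 1 to compound 3 (0.41 log units; beyond the scatter), a modest gain from putting methyl where hydrogen was; the other step, a 1.0-fold lower number from compound 1 to compound 2 (0.01 log units; within the scatter), concerns the bromo and stays within the scatter. Whether cyano keeps the gain that methyl brought, or falls back toward the numbers of compound 1 and compound 2, cannot be read from these three compounds. The expectation is therefore a number near that of compound 3, with the range opened toward the weaker side. For compound 4 in this assay the estimate is 5500 nM, between 1800 nM and 17000 nM. That estimate means a step of a 1.3-fold higher number from compound 3 to compound 4 (0.11 log units; within the scatter), expected not to exceed the scatter.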

Compound 4, half-maximal effective concentration: 6920 nM
Estimate against measurement, compound 4: 1.3-fold (0.10 log units) below, and the stated range covers the measured number.
By their numbers in this assay, from the lowest: compounds 3, 4, 2 and 1 (each within the scatter of the next, the first and the last beyond it).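

In this assay, replacing methyl with cyano at the carbon para to a large group gives a 1.6-fold higher number from compound 3 to compound 4 (0.21 log units; within the scatter) and replacing hydrogen with cyano gives a 1.6-fold lower number from compound 1 to compound 4 (0.20 log units; within the scatter), so compound 4 cannot be told apart from either neighbour. The hydrogen and methyl compounds do separate, with a 2.6-fold lower number from compound 1 to compound 3 (0.41 log units; beyond the scatter) as the step, which leaves the cyano result unassigned: it neither retains nor loses that gain in any readable way. The carbon does accept a nitrile, which adds a hydrogen-bond acceptor by count, with no step beyond the scatter. No supporting measurement bears on the reason for these numbers. From the compounds shown here alone, whether an amine or a carboxylic acid at this carbon would move the number beyond the scatter remains open. Also open, going by these compounds, is whether methyl or cyano here behaves the same without the bromo on the core.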